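The compounds below may be only part of what the source reports. "The series", "measured", "known", "first", "only" and "open" are said of these compounds alone.

Compound 3 `Cc1cc(NC(=O)Nc2ccc(C(N)=O)cc2)c2ccccc2n1` is the starting point. In an ADME assay on Raji cells (Homo sapiens) for cytotoxicity, with a stated time of 72 h (on this read-out lower numbers stand for an effect already at smaller amounts and higher numbers for an effect only at larger amounts of compound), compound 3 gives only a limit, > 25000 nM, not a number. Compound 2 `Cc1cc(NC(=O)Nc2ccc(N(C)C)cc2)c2ccccc2n1` likewise gives only a limit in this assay, > 25000 nM. Compound 1 `COC(=O)c1ccc(NC(=O)Nc2cc(C)nc3ccccc23)cc1` gives a number in this assay, 17000 nM, so compound 3 cannot be set apart from the others; it rests at the limit of > 25000 nM in this assay, at which 2 of the 3 values shown sit. The step to compound 4 `CCc1ccc(NC(=O)Nc2cc(C)nc3ccccc23)cc1` changes one place: ethyl in place of carbamoyl on an aromatic carbon. Among the measured compounds shown here, no measured step swaps a carbamoyl for an ethyl; the nearest are an at least 1.4-fold higher number from compound 1 to compound 3 (0.16 log units; that floor lies within the scatter) and an at least 1.4-fold higher number from compound 1 to compound 2 (0.16 log units; that floor lies within the scatter), both only floors within the scatter, and a step that the two limits leave unreadable from compound 2 to compound 3. With every measured value either at the limit or within scatter of it, compound 4 is expected to sit in the same region, the estimated step being an at least 1.2-fold lower number from compound 3 to compound 4 (0.09 log units; that floor lies within the scatter). Compound 4 is therefore estimated at 20000 nM, within 8000 nM and 40000 nM, with a real chance that this assay again returns only a limit.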

Compound 4, half-maximal effective concentration: > 25000 nM
Compound 4 was reported as a limit (the forecaster's own chance of this, stated with the estimate: 50%); middle value at least 1.2-fold (0.09 log units) from the limit.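

Ethyl, with no hydrogen-bond donors or acceptors, replaces carbamoyl, which has both, yet in this assay compound 4 still returns only a limit, so very different groups at this place on the ring end at the same ceiling: the limit of > 25000 nM in this assay, at which 3 of the 4 values shown sit. The steps to compound 4 from compound 2 and from compound 3 cannot be read, as both ends of each are limits. Among the compounds shown here, the only readable step, an at least 1.4-fold higher number from compound 1 to compound 4 (0.16 log units; that floor lies within the scatter), gives no clear separation of ethyl from methoxycarbonyl.

As far as these compounds go, how far the true values of compound 2, compound 3 and compound 4 lie past the limit remains unknown. Also open, from the compounds shown here alone, is whether a carboxylic acid or a longer chain at this place would give a number clearly apart from that of compound 1.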